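Swapping a phenyl for a carboxy on a naphthol inhibitor

This account rests on a few compounds, and the source may have more. Where it says the series, first, only, none or still open, it means among the compounds named here.

Measured so far:
compound 1, `Cc1ccc(Cc2ccc3ccccc3c2O)cc1`, 24 nM
compound 2, `Oc1c(Cc2cccc(Oc3ccccc3)c2)ccc2ccccc12`, 83 nM
compound 3, `Oc1c(Cc2ccccc2)cc(-c2ccccc2)c2ccccc12`, 56 nM

Three benzyl-substituted naphthols have been tested in an assay on RBL-1 cells with Polyunsaturated fatty acid 5-lipoxygenase (Rattus norvegicus) as the target; a lower number here means a stronger inhibitor, a higher number a weaker inhibitor. Compound 3 holds the second highest number of the three; its value sits within the scatter of compound 2, so the two cannot be ordered, while compound 1 gives a number beyond the scatter lower than compound 3.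

Compound 4, `O=C(O)c1cc(Cc2ccccc2)c(O)c2ccccc12`, has not yet been measured. It differs from compound 3 in one place: carboxy in place of phenyl on an aromatic carbon. Among the measured compounds shown here, no measured pair shows this kind of change, so its effect is unknown. A step toward a higher number, beyond the scatter, is expected for compound 4, which is estimated at 160 nM (range 40 nM to 650 nM), a change of a 2.9-fold higher number from compound 3 to compound 4 (0.46 log units; beyond the scatter) from its parent.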

Compound 4, half-maximal inhibitory concentration: 5800 nM
Compound 4: middle estimate off by 36-fold (1.56 log units), on the low side, and the stated range ends below it.
By their numbers in this assay, from the lowest: compound 1; then compounds 3 and 2 (each within the scatter of the next); then compound 4.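

In this assay, carboxy in place of phenyl on this aromatic carbon, para to a hydroxy group, gives a 100-fold higher number from compound 3 to compound 4 (2.02 log units; beyond the scatter), showing that the group here can strongly affect the number. The change swaps a carbon-only ring for a smaller group with oxygen and hydrogen-bond donor and acceptor atoms, so this single step cannot separate ring loss from carboxy gain. No measurement here explains the rise. On these data alone, it remains open whether a methyl ester, a primary amide or a simple methyl at this position would bring the number back down.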